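Hydroxy for methyl on the chain across two cores

The source may report more compounds than this note shows. Statements on the series, on what has been measured and on what is new or still open speak of the compounds shown alone.

The set comprises compound 1 `CN(CCO)/N=N/c1ccccc1C(N)=O`, compound 3 `CCCN(C)/N=N/c1ccccc1C(N)=O`, compound 2 `CCCN(C)/N=N/c1n[nH]cc1C(N)=O` and the still unmeasured compound 4 `CN(CCO)/N=N/c1n[nH]cc1C(N)=O`. In a functional assay on L1210 cells (Mus musculus) for antiproliferative activity (a higher number here means a more potent compound, by a factor of ten per unit of this negative logarithm, a lower number a less potent compound), compound 3 gives 3.26, compound 1 gives 3.07 and compound 2 gives 3.7. Compound 2 holds the highest of the three measured numbers, and its separation from both compound 3 and compound 1 is beyond the scatter. The difference between the core of compound 2 and the core of compound 3 is not broken down here.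

One structural change has a measured step: hydroxy in place of methyl on a saturated chain carbon, two bonds along the chain from an amine nitrogen. That step, a number 0.19 log units lower from compound 3 to compound 1 (within the scatter), sits within the scatter. The same change, occurring twice among the compounds shown, is now made on the other core: hydroxy in place of methyl on a saturated chain carbon, two bonds along the chain from an amine nitrogen. The place is described in identical words on both cores, so the change is taken as the same. A near-flat step is expected from compound 2 to compound 4, a number 0.20 log units lower from compound 2 to compound 4 (within the scatter), because a number 0.19 log units lower from compound 3 to compound 1 (within the scatter) stayed within the scatter. Compound 4 is therefore estimated at 3.5, expected to lie between 3.1 and 3.9.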

Compound 4, logarithm of the reciprocal of the active concentration, log(1/C): 3.1
Compound 4: the middle estimate sits 0.40 log units above what was measured; the measured number falls inside the stated range.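

On the core of compound 2, hydroxy in place of methyl gives a number 0.60 log units lower from compound 2 to compound 4 (beyond the scatter) in this assay, while the same change on the other core gives a number 0.19 log units lower from compound 3 to compound 1 (within the scatter) in that assay. One step lies within the scatter and the other beyond it, yet the two cannot be told apart, so the change can be read as carrying over between these two cores: the same change on two cores in this assay, a number 0.19 log units lower (within the scatter) from compound 3 to compound 1 and a number 0.60 log units lower (beyond the scatter) from compound 2 to compound 4, 0.41 log units apart, within the scatter of two such steps. This rests on a single pair of steps in one assay, so it does not fix the size of the change on either core and does not show that the change would carry over to any further core.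

Still open, going by these compounds, is how other groups at this place, on a saturated chain carbon, two bonds along the chain from an amine nitrogen, would compare, for example an amine, a carboxylic acid or a longer chain. The compounds shown also leave open whether the step between methyl and hydroxy would hold in a read-out other than antiproliferative activity.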